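Imidazoline in Place of Methylimidazole: Expectation for Compound 4

This account rests on a few compounds, and the source may have more. Where it says the series, first, only, none or still open, it means among the compounds named here.

Measured so far:
compound 1 `O=S(=O)(Nc1cccc2c1CCCC2c1c[nH]cn1)C1CC1` gives 537 nM
compound 2 `Cn1cnc(C2CCCc3c(NS(C)(=O)=O)cccc32)c1` gives 275 nM
compound 3 `Cn1cncc1C1CCCc2c(NS(C)(=O)=O)cccc21` is recorded only as a limit, < 10000 nM

In an assay on isolated protein for binding affinity to Alpha-1A adrenergic receptor (Rattus norvegicus), read by radioligand binding (on this read-out higher numbers stand for weaker inhibition and lower numbers for stronger inhibition), compound 1 gives 537 nM and compound 2 gives 275 nM. For compound 3 the read-out is a limit of the assay and not a number, < 10000 nM. Of the three values shown, one sits at this limit (the limit of < 10000 nM in this assay, at which 1 of the 3 values shown sits). Among the compounds with values here, the single step that touches compound 3, a step that the limit leaves unreadable from compound 2 to compound 3, therefore cannot be sized, and nothing can be said about where compound 3 stands relative to compound 1 or compound 2 beyond the limit itself.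

Compound 4 `CS(=O)(=O)Nc1cccc2c1CCCC2C1=NCCN1` differs from compound 3 in one place: a group of 5 heavy atoms (3 carbon, 2 nitrogen; one five-membered non-aromatic ring with 2 hetero atoms) in place of a group of 6 heavy atoms (4 carbon, 2 nitrogen; one five-membered aromatic ring with 2 hetero atoms), on a saturated ring carbon. Within the data shown here, none of the measured steps covers this change, and the only step that involves compound 3 is unreadable, so no size or direction can be carried over from the data. The expectation for compound 4 rests solely on the range spanned by compound 1 and compound 2 in this assay. Compound 4 is accordingly expected to give about 400 nM, with a range from 40 nM to 4000 nM. The step this estimate implies, a step that the limit leaves unreadable from compound 3 to compound 4, is expected only as a departure from the limit recorded for compound 3, not as a measured-against change.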

Compound 4, inhibition constant: 457 nM
Compound 4: middle estimate off by 1.1-fold (0.06 log units), on the low side, within the range that was stated.
By their numbers in this assay, from the lowest: compounds 2, 4 and 1 (each within the scatter of the next).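

In this assay, the five-membered non-aromatic ring with 2 hetero atoms of compound 4, in place of the 1-methyl-1H-imidazol-4-yl group on the same saturated ring carbon, gives a 1.7-fold higher number from compound 2 to compound 4 (0.22 log units; within the scatter). Within the data shown here, this is the first readable change of ring type at this position: the aromatic ring gives way to a non-aromatic ring carrying 1 double bond outside aromatic rings and 1 hydrogen-bond donor, and the two values stay within the scatter of each other, so the data show no loss or gain from this exchange. The steps that touch compound 3 cannot be read, so the exchange against the 1-methyl-1H-imidazol-5-yl group has no size, because the value of compound 3 is a limit: the limit of < 10000 nM in this assay, at which 1 of the 4 values shown sits.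

The compounds shown leave open how a primary amine or an open-chain amidine would read on this saturated ring carbon. They also leave open how the ring of compound 4 would read with a cyclopropyl group in place of the methyl group on the sulfonyl, or with a longer alkyl chain there.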